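The source may report more compounds than this note shows. Statements on the series, on what has been measured and on what is new or still open speak of the compounds shown alone.

Measured so far:
compound 1 `O=C(COCc1ccccc1)N1CCN(c2ccccc2Cl)CC1` — 1100 nM
compound 2 `O=C(COCc1ccccn1)N1CCN(c2ccc(Cl)cc2Cl)CC1` — 310 nM

In a functional assay on HEK293 cells for positive allosteric modulation of metabotropic glutamate receptor 5 (Homo sapiens), read by FLIPR and calcium flux (on this read-out lower numbers stand for an effect already at smaller amounts and higher numbers for an effect only at larger amounts of compound), compound 2 gives 310 nM, the lowest of the two numbers shown; compound 1 stands higher, a gap beyond the usual scatter. The two differ in more than one place, so no single step can be read from them.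

Compound 3 `O=C(COCc1nccs1)N1CCN(c2ccc(Cl)cc2Cl)CC1` carries 1,3-thiazol-2-yl in place of pyridin-2-yl on a saturated chain carbon bound to an oxygen on a saturated carbon. Within the data shown here, no measured pair shows this exchange, so the expected step of a 1.3-fold higher number from compound 2 to compound 3 (0.11 log units; within the scatter) is a small one, likely within the scatter, with no clear direction. For compound 3 the estimate in this assay is 400 nM, expected between 150 nM and 1100 nM.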

Compound 3, half-maximal effective concentration: 10300 nM
Estimate against measurement, compound 3: 26-fold (1.41 log units) below, outside the stated range (above it).
By their numbers in this assay, from the lowest: compound 2; then compound 1; then compound 3.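

In this assay, the change of pyridin-2-yl to 1,3-thiazol-2-yl on a saturated chain carbon bound to an oxygen on a saturated carbon gives a 33-fold higher number from compound 2 to compound 3 (1.52 log units; beyond the scatter). This place therefore does not accept every small aromatic ring equally, even with the rest of compound 2 unchanged. Nothing at hand accounts for the size of this step.

Still open, on these data alone, is whether the step follows from the five-membered ring or from its sulfur, which a 1,3-oxazol-2-yl or pyrimidin-2-yl group could help separate. Compound 1 differs from compound 2 in more than one place, so the separate share of each difference stays unresolved.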